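Swapping the Aryl Group Again on the Hydroxamic Acid Core

The source may report more compounds than this note shows. Statements on the series, on what has been measured and on what is new or still open speak of the compounds shown alone.

Among the measured compounds shown here, in a functional assay on SK-OV-3 cells (Homo sapiens) for cytotoxicity (a lower number here means a stronger inhibitor, a higher number a weaker inhibitor), compound 2 `CN(C)c1ccc(-c2ccc3nc(CCCCCCC(=O)NO)[nH]c3c2)cc1` gives 6600 nM, the lowest of the two numbers measured so far. For the measured compounds named here, its only neighbour, compound 1 `O=C(CCCCCCc1nc2ccc(-c3ccccc3F)cc2[nH]1)NO`, gives 7400 nM, and the step of a 1.1-fold lower number from compound 1 to compound 2 (0.05 log units; within the scatter), a 4-(dimethylamino)phenyl in place of 2-fluorophenyl on an aromatic carbon, stayed within the scatter. Compound 3 `O=C(CCCCCCc1nc2ccc(-c3cncnc3)cc2[nH]1)NO` differs from compound 2 by pyrimidin-5-yl in place of 4-(dimethylamino)phenyl on an aromatic carbon. Going by the values given here, the one earlier swap of the aryl group at this place, a 1.1-fold lower number from compound 1 to compound 2 (0.05 log units; within the scatter), barely moved the number, so no step beyond the scatter is expected here. Compound 3 is estimated at 7000 nM, between 3000 nM and 16000 nM. That estimate means a 1.1-fold higher number from compound 2 to compound 3 (0.03 log units; within the scatter) is expected.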

Compound 3, half-maximal inhibitory concentration: 2600 nM
Compound 3: middle estimate off by 2.7-fold (0.43 log units), on the high side; the whole stated range lies above it.
By their numbers in this assay, from the lowest: compound 3; then compounds 2 and 1 (each within the scatter of the next).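

At this place on the shared core, the aryl group can shift the number after all. In this assay, pyrimidin-5-yl gives a 2.5-fold lower number from compound 2 to compound 3 (0.40 log units; beyond the scatter) and a 2.8-fold lower number from compound 1 to compound 3 (0.45 log units; beyond the scatter), whereas the two aryl groups with carbon-only rings stayed within the scatter of each other. No measurement here explains these steps.

The compounds shown leave open whether the lower number goes with the nitrogen atoms in the ring or with the group's smaller size. From the compounds shown here alone, how a pyridin-3-yl or a plain phenyl group would compare at this place also remains open.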